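This account rests on a few compounds, and the source may have more. Where it says the series, first, only, none or still open, it means among the compounds named here.

Three compounds share one core and were examined in an assay on cells for inhibition of Palmitoleoyl-protein carboxylesterase NOTUM variant C330S (Homo sapiens), read by fluorescence, with a stated time of 40 min; on this read-out higher numbers stand for weaker inhibition and lower numbers for stronger inhibition. Compound 1 `Cc1cc(C(=O)O)c(C)n1-c1cccc(C#N)c1F` gives 630 nM, the second highest of the three numbers. Compound 3 `Cc1cc(C(=O)O)c(C)n1-c1ccc(Cl)cc1Cl` gives 430 nM, within the scatter of compound 1. Going by the values given here, compound 2 `Cc1cc(C(=O)O)c(C)n1-c1cccc(C#N)c1` gives 3100 nM, and the step of a 4.9-fold higher number from compound 1 to compound 2 (0.69 log units; beyond the scatter) is the only single-point change measured here. Compound 4 `Cc1cc(C(=O)O)c(C)n1-c1cccc(C(C)C)c1F` differs from compound 1 by isopropyl in place of cyano on an aromatic carbon. Among the compounds with values here, no measured step shows the exchange of a cyano for an isopropyl, and the fluoro is retained, so the one known step does not bear on this change. Compound 4 is therefore expected to stay within the scatter of compound 1, its estimated step being a 1.1-fold lower number from compound 1 to compound 4 (0.02 log units; within the scatter). Compound 4 is estimated at 600 nM, within a range from 150 nM to 2500 nM.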

Compound 4, half-maximal inhibitory concentration: 150 nM
Compound 4: the middle estimate sits 4.0-fold (0.60 log units) above what was measured, and the stated range covers the measured number.
By their numbers in this assay, from the lowest: compound 4; then compounds 3 and 1 (each within the scatter of the next); then compound 2.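

On the shared core, the aromatic carbon that holds the cyano group in compound 1 accepts a change to isopropyl, with the fluoro retained, and this assay gives a 4.2-fold lower number from compound 1 to compound 4 (0.62 log units; beyond the scatter). The cyano group is therefore not required at this position, as a group with no hydrogen-bond acceptor gives stronger inhibition here. Nothing available explains this gain. From the compounds shown here alone, it remains open how a tert-butyl group, a longer chain or an amine would fare on this carbon. Going by these compounds, it is also open whether hydrogen in place of fluoro would cost as much with isopropyl present as it does with cyano.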